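Pyridin-3-yl to pyridin-4-yl swap in a cytotoxicity series

The source may hold more compounds than are shown below. What is called first, only, known or untested is meant among the compounds shown, and "the series" means these compounds.

Compound 1 `COc1cc(/C=C2\CN(C)C/C(=C\c3cccnc3)C2=O)cc(OC)c1OC` and compound 3 `COc1cc(/C=C2\CN(C)C/C(=C\c3ccncc3)C2=O)cc(OC)c1OC` share one core and differ only by pyridin-4-yl in place of pyridin-3-yl on a double-bonded chain carbon bound to a double-bonded ring carbon. In a functional assay on HepG2 cells (Homo sapiens) for cytotoxicity, read by MTT assay, with a stated time of 24 h (a higher number here means a weaker inhibitor, a lower number a stronger inhibitor), compound 1 gives 9520 nM and compound 3 gives 9800 nM; the step of a 1.0-fold higher number from compound 1 to compound 3 (0.01 log units; within the scatter) leaves the read-out essentially where it was. Compound 2 `CN1C/C(=C\c2cccnc2)C(=O)/C(=C/c2ccccc2F)C1` is built on another core; the difference between the core of compound 2 and that of compound 1 is not broken down here. In this assay compound 2 gives 4810 nM, a value within the scatter of compound 1 but beyond the scatter relative to compound 3. Going by the values given here, compound 4 `CN1C/C(=C\c2ccncc2)C(=O)/C(=C/c2ccccc2F)C1` has not yet been measured; it relates to compound 2 by pyridin-4-yl in place of pyridin-3-yl on a double-bonded chain carbon bound to a double-bonded ring carbon, the same change, at the same place, as the one made from compound 1 to compound 3. Since that change gave a 1.0-fold higher number from compound 1 to compound 3 (0.01 log units; within the scatter), a similarly small step is expected here as well, a 1.0-fold higher number from compound 2 to compound 4 (0.01 log units; within the scatter). Compound 4 is therefore estimated at 4900 nM in this assay, with a likely range from 2400 nM to 9800 nM. Among the compounds with values here, only one earlier instance of the change is available, so this estimate remains provisional.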

Compound 4, half-maximal inhibitory concentration: 4600 nM
Estimate against measurement, compound 4: 1.1-fold (0.03 log units) above; low and high end bracket the measured number.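

Pyridin-4-yl in place of pyridin-3-yl has now been read on two cores, and in this assay the step on the core of compound 2 is a 1.0-fold lower number from compound 2 to compound 4 (0.02 log units; within the scatter), which leaves the read-out essentially unchanged. The two steps agree: the same change on two cores in this assay, a 1.0-fold higher number (0.01 log units; within the scatter) from compound 1 to compound 3 and a 1.0-fold lower number (0.02 log units; within the scatter) from compound 2 to compound 4, 1.1-fold (0.03 log units) apart, within the scatter of two such steps
Within these two pairs, the swap therefore carries from one core to the other with no visible effect on the read-out. This does not show that it would stay as small on a third core, and two steps within the scatter give no reason for the agreement.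

Only two pyridine attachments are covered here, so the series leaves open how pyridin-2-yl would behave on a double-bonded chain carbon bound to a double-bonded ring carbon. Also open, from the compounds shown here alone, is whether a pyridine ring carrying an amine or a carboxylic acid would move the number on either core.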